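Swapping the aryl group on the triazole of a shared core

A few compounds are considered here, and "the series" means these few. Any claim that something is new, unique, unknown or untested is made for them only; others in the source may bear on it.

Of the compounds shown here, three built on one shared core have been tested in a functional assay on SW480 cells (Homo sapiens) for cytotoxicity, read by MTT assay, with a stated time of 4 days; a lower number here means a stronger inhibitor, a higher number a weaker inhibitor. Compound 1 `C=C1C(=O)[C@]23C[C@@]1(O)CC[C@H]2c1ccc(O)c(C)c1[C@@H]3Cn1cc(-c2ccc(Br)cc2)nn1` gives 310 nM. Compound 2 `C=C1C(=O)[C@]23C[C@@]1(O)CC[C@H]2c1ccc(OS(=O)(=O)c2ccc(C)cc2)c(C)c1[C@@H]3Cn1cc(-c2ccc(F)cc2)nn1` gives 1630 nM. Compound 3 `C=C1C(=O)[C@]23C[C@@]1(O)CC[C@H]2c1ccc(O)c(C)c1[C@@H]3Cn1cc(-c2ccccn2)nn1` gives 410 nM, which places compound 3 second highest of the three numbers: its nearest neighbour is compound 1, within the scatter, and its furthest is compound 2, beyond the scatter.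

The change from compound 3 to compound 4 `C=C1C(=O)[C@]23C[C@@]1(O)CC[C@H]2c1ccc(O)c(C)c1[C@@H]3Cn1cc(-c2ccc(F)cc2)nn1` is 4-fluorophenyl in place of pyridin-2-yl on an aromatic carbon. For the measured compounds named here, only one measured step bears on this place in the structure: a 1.3-fold higher number from compound 1 to compound 3 (0.12 log units; within the scatter), a change of aryl group at the same carbon that stayed within the scatter. Compound 2 also carries a 4-fluorophenyl group, but it differs from compound 3 in a second place as well, so all its value shows is that compound 2 can reach 1630 nM when another part of the core is also altered.

Going by the values given here, because the one comparable step, a 1.3-fold higher number from compound 1 to compound 3 (0.12 log units; within the scatter), was within the scatter, compound 4 is expected to show a 1.2-fold lower number from compound 3 to compound 4 (0.07 log units; within the scatter), that is, no step beyond the scatter. The estimate for compound 4 is therefore 350 nM, with a likely range from 150 nM to 850 nM.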

Compound 4, half-maximal inhibitory concentration: 250 nM
Compound 4: the middle estimate sits 1.4-fold (0.15 log units) above what was measured, and the stated range covers the measured number.
By their numbers in this assay, from the lowest: compounds 4, 1 and 3 (each within the scatter of the next); then compound 2.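

At this aromatic carbon of the five-membered ring with 3 nitrogen, 4-fluorophenyl, 4-bromophenyl and pyridin-2-yl cannot be told apart in this assay (a 1.6-fold lower number from compound 3 to compound 4 (0.21 log units; within the scatter); a 1.2-fold lower number from compound 1 to compound 4 (0.09 log units; within the scatter)), so losing the ring nitrogen of pyridin-2-yl, the group's only hydrogen-bond acceptor, moves the number no further than the scatter. For the compounds shown here, compound 4 also gives the first single-place reading of the oxygen on the aromatic ring, where hydrogen in place of (4-methylphenyl)sulfonyl gives the only step here beyond the scatter (a 6.5-fold lower number from compound 2 to compound 4 (0.81 log units; beyond the scatter)), so the higher number of compound 2 goes with that sulfonyl group and not with its 4-fluorophenyl. Nothing measured here explains either result.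

Still open, as far as these compounds go, is whether this carbon accepts anything other than a six-membered aromatic ring, such as an amine, a carboxylic acid or a longer alkyl chain. Also open, from the compounds shown here alone, is how smaller groups on that oxygen, such as methyl or acetyl, would compare with hydrogen.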